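Hydroxymethyl on the terminal alkyne of compound 1

The source may report more compounds than this note shows. Statements on the series, on what has been measured and on what is new or still open speak of the compounds shown alone.

Of the compounds shown here, three have been measured in a functional assay on T47D cells (Homo sapiens) for antiproliferative activity, with a stated time of 72 h; a lower number here means a stronger inhibitor, a higher number a weaker inhibitor. Compound 1 `C#CCSc1cnc2ccccc2c1[Se]CC#CCCl` gives 0.4 ug/mL, the lowest of the three numbers. Compound 2 `CSc1cnc2ccccc2c1[Se]CC#CCOC(=O)c1ccccc1` gives 2.2 ug/mL in this assay, and compound 3 `CCOC(=O)OCC#CCSc1c(SC)cnc2ccccc12` gives 34.2 ug/mL; both stand beyond the scatter from compound 1, compound 3 by the wider margin. Going by the values given here, no two measured compounds differ in one place only, so no single-change step is available to calibrate the next one.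

Compound 4 `OCC#CCSc1cnc2ccccc2c1[Se]CC#CCCl` has not yet been measured in this assay. Its change from compound 1 is hydroxymethyl in place of hydrogen on a triple-bonded carbon. The entering group is small, two heavy atoms, and carries one hydrogen-bond donor and one acceptor; it sits on a triple-bonded carbon whose other neighbour is a triple-bonded carbon.

Among the compounds with values here, with no measured step to lean on, the expected step for compound 4 in this assay is a 1.8-fold higher number from compound 1 to compound 4 (0.24 log units; within the scatter), a slight weakening that may not clear the scatter. For compound 4 the estimate in this assay is 0.7 ug/mL, with a range from 0.2 ug/mL to 2.5 ug/mL.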

Compound 4, concentration for 50% inhibition: 1.7 ug/mL
The estimate for compound 4 lay 2.4-fold (0.39 log units) below the measured number; the measured number falls inside the stated range.
By their numbers in this assay, from the lowest: compound 1; then compounds 4 and 2 (each within the scatter of the next); then compound 3.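

In this assay, the series now has its first single-change step: hydroxymethyl in place of hydrogen on a triple-bonded carbon gives a 4.3-fold higher number from compound 1 to compound 4 (0.63 log units; beyond the scatter), a modest weakening beyond the scatter. The terminal alkyne position of compound 1 is therefore not neutral to this change, although this single step shows that the substitution costs only modestly here. Nothing available accounts for the size or direction of this step.

Still open, going by these compounds, is whether the step belongs to the hydroxyl or to the added carbon, a question that a methyl or methoxymethyl group on the same triple-bonded carbon would address. Also open, on these data alone, is whether an amine in place of the hydroxyl, or a longer chain ending in hydroxyl, would move the number in the same direction.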